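The compounds below may be only part of what the source reports. "The series", "measured", "known", "first", "only" and "open" are said of these compounds alone.

In a physicochemical assay for lipophilicity (a higher number here means a more lipophilic compound, a lower number a more polar compound), compound 1 `CNC(=O)c1cc(C(=O)N[C@H]2CC[C@H](O)CC2)n([C@@H](C)c2ccc(Cl)cc2)n1` gives 3.7 and compound 2 `CNC(=O)c1cc(C(=O)N[C@H]2CC[C@H](O)CC2)c([C@@H](C)c2cccc(Cl)c2)o1` gives 3.5, so the two values lie within the usual scatter of each other. Compound 3 `CNC(=O)c1cc(C(=O)N[C@H]2CC[C@H](O)CC2)c([C@@H](C)c2ccc(Cl)cc2)o1` has not yet been measured and differs from compound 2 by 4-chlorophenyl in place of 3-chlorophenyl on a saturated chain carbon bound to an aromatic carbon and a saturated chain carbon. For the measured compounds named here, the two have the same atoms, joined differently, and no measured pair shows this change. A shift beyond the scatter is therefore not expected. The estimated change is a number 0.10 log units higher from compound 2 to compound 3 (within the scatter). For compound 3, the expected value in this assay is 3.6, with an estimated range of 3.2 to 4.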

Compound 3, distribution coefficient: 3.5
Estimate against measurement, compound 3: 0.10 log units above; the range from low to high includes it.
By their numbers in this assay, from the lowest: compounds 2, 3 and 1 (each within the scatter of the next).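

In this assay, for the compounds shown here, 4-chlorophenyl in place of 3-chlorophenyl on a saturated chain carbon bound to an aromatic carbon and a saturated chain carbon gives no change at the digits printed from compound 2 to compound 3 (within the scatter), the first step that isolates this change. For this pair, the two chlorophenyl isomers cannot be told apart in this measurement. Nothing available explains the step.

Still open, as far as these compounds go, is how a carboxylic acid or an amine on the phenyl ring in place of the chlorine would read at this position. Also open, from the compounds shown here alone, is whether the same exchange on the core of compound 1 would read the same way.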